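The compounds below may be only part of what the source reports. "The series", "measured", "known", "first", "only" and "open" are said of these compounds alone.

Compound 1 `C[C@@H](CO)Nc1nc(C(=O)NCc2ccc(F)cc2)c(O)c2ncccc12` was examined in a functional assay on MDA-MB-435 cells (Homo sapiens) for cytotoxicity, read by MTT assay, with a stated time of 72 h; a lower number here means a stronger inhibitor, a higher number a weaker inhibitor. In this assay compound 1 reaches only the limit, > 20000 nM, so it sits at the limit of > 20000 nM in this assay, at which 1 of the 2 values shown sits, rather than at a number. Compound 2 `N[C@H]1CC[C@H](Nc2c(C(=O)NCc3ccc(F)cc3)nc(Br)c3cccnc23)CC1` gives 6000 nM in this assay. Compound 3 `O=CNCCCCCCNc1nc(C(=O)NCc2ccc(F)cc2)c(O)c2ncccc12` carries a change at one place: 6-(formylamino)hexyl in place of 1-(hydroxymethyl)ethyl on a nitrogen on an aromatic ring, a 6-(formylamino)hexyl in place of the 1-(hydroxymethyl)ethyl on the aromatic nitrogen. The step from compound 1 to compound 3 is expected to be a modest gain in this assay, an at least 1.3-fold lower number from compound 1 to compound 3 (0.12 log units; that floor lies within the scatter). Compound 3 is estimated at 15000 nM, between 4000 nM and 60000 nM.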

Compound 3, half-maximal inhibitory concentration: 16000 nM
Compound 3: the middle estimate sits 1.1-fold (0.03 log units) below what was measured, within the range that was stated.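

On the aromatic nitrogen, 6-(formylamino)hexyl in place of 1-(hydroxymethyl)ethyl gives, in this assay, an at least 1.2-fold lower number from compound 1 to compound 3 (0.09 log units; that floor lies within the scatter). Compound 3 shows that this position takes the longer chain and still gives a number rather than a limit. The value of compound 1 is a limit, so the step has only a floor: the limit of > 20000 nM in this assay, at which 1 of the 3 values shown sits.

Going by these compounds, whether the chain length or the formylamino end carries the step remains open. So does what an amine or a carboxylic acid at the end of the chain would give on the shared core.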